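The source may hold more compounds than are shown below. What is called first, only, known or untested is meant among the compounds shown, and "the series" means these compounds.

Measured compounds:
compound 1 `N#Cc1ccc(C(Nc2ccc(C(=O)O)cc2)c2ccc3cccnc3c2O)cc1` – 16000 nM
compound 2 `Cc1ccc(NC(c2ccccc2)c2ccc3cccnc3c2O)cc1` – 8800 nM
compound 3 `CCOC(=O)c1ccc(NC(c2ccc(C(F)(F)F)cc2)c2ccc3cccnc3c2O)cc1` – "not determined" (no result reported)

In an assay on isolated protein for inhibition of CAAX prenyl protease 2 (Homo sapiens), with stated times of 60 s and 60 min (on this read-out lower numbers stand for stronger inhibition and higher numbers for weaker inhibition), compound 1 gives 16000 nM. In this assay compound 2 gives 8800 nM, and the gap between compound 1 and compound 2 lies within the usual scatter of repeated measurements, so on these two numbers compound 1 is not set apart from compound 2. For compound 3 no result in this assay was reported, so it adds nothing to the comparison.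

Compound 4 `O=C(O)c1ccc(NC(c2ccccn2)c2ccc3cccnc3c2O)cc1` is built on the shared core of compound 1 and differs from it in one place: pyridin-2-yl in place of 4-cyanophenyl on a saturated chain carbon bound to an aromatic carbon and a nitrogen on an aromatic ring. Within the data shown here, no pair of measured compounds isolates this change, so there is no measured step to lean on, and the two numbers available give no hint that an aryl swap at this position moves the read-out beyond the scatter. On that basis compound 4 is expected to sit close to compound 1, with a step of a 1.2-fold lower number from compound 1 to compound 4 (0.09 log units; within the scatter) that is not expected to exceed the scatter. The estimate for compound 4 in this assay is 13000 nM, with a range from 4000 nM to 45000 nM.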

Compound 4, half-maximal inhibitory concentration: 38000 nM
Compound 4: the middle estimate sits 2.9-fold (0.47 log units) below what was measured; the range from low to high includes it.
By their numbers in this assay, from the lowest: compounds 2 and 1 (each within the scatter of the next); then compound 4.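

In this assay the group on a saturated chain carbon bound to an aromatic carbon and a nitrogen on an aromatic ring turns out not to be freely exchangeable: pyridin-2-yl in place of 4-cyanophenyl gives a 2.4-fold higher number from compound 1 to compound 4 (0.38 log units; beyond the scatter) as a modest loss of inhibition. Among these compounds, the earlier compounds offered no pair differing in one place, so this single step is the first direct reading of this position, and it points toward weaker inhibition. No measurement among those shown accounts for the step.

Whether the step follows the ring nitrogen that enters or the nitrile that leaves stays unresolved with one pair of compounds. As far as these compounds go, what pyridin-4-yl or 4-aminophenyl would do at this place also remains open.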